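A few compounds are considered here, and "the series" means these few. Any claim that something is new, unique, unknown or untested is made for them only; others in the source may bear on it.

Measured so far:
compound 1 `CCCCCc1cc2cn([C@H]3C[C@H](O)[C@@H](CO)O3)c(=O)nc2o1` — > 50000 nM
compound 2 `CCCCCCc1cc2cn([C@H]3C[C@H](O)[C@@H](CO)O3)c(=O)nc2o1` — 200000 nM

In a functional assay on HEL cells (Homo sapiens) for cytotoxicity (on this read-out lower numbers stand for higher toxicity in this test and higher numbers for lower toxicity in this test), compound 1 gives only a limit, > 50000 nM. In this assay compound 2 gives 200000 nM, the only number shown. The step that the limit leaves unreadable from compound 1 to compound 2 therefore cannot be read, because of the limit of > 50000 nM in this assay, at which 1 of the 2 values shown sits. Compound 3 `CCCCCCCc1cc2cn([C@H]3C[C@H](O)[C@@H](CO)O3)c(=O)nc2o1` differs from compound 2 by methyl in place of hydrogen on a saturated chain carbon, six bonds along the chain from an aromatic carbon. No readable step bears on this change, so no move beyond the scatter is expected for the step of no change at the digits printed from compound 2 to compound 3 (within the scatter). Compound 3 is estimated at 200000 nM, between 60000 nM and 600000 nM.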

Compound 3, minimum cytotoxic concentration: > 50000 nM
Compound 3: a limit, no number; the forecaster's own chance of this, stated with the estimate: 40%; the middle value does not contradict the limit.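

No step among compound 1, compound 2 and compound 3 can be read in this assay, and the reason is a limit, not a number: the limit of > 50000 nM in this assay, at which 2 of the 3 values shown sit.

Going by these compounds, whether chain length on the shared core affects the result in this assay at all stays open.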